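Working notes: tolerated concentration across a shared-core amide series

A few compounds are considered here, and "the series" means these few. Any claim that something is new, unique, unknown or untested is made for them only; others in the source may bear on it.

Measured in an ADME assay on MDBK cells (Bos taurus) for cytotoxicity, read by MTT assay, with a stated time of 96 h; a lower number here means that less compound is tolerated, a higher number that more compound is tolerated:
compound 1 `CN1CCN(CC(=O)Nc2ccc(-c3nc4cc(C(F)(F)F)ccc4n3C)cc2)CC1` gives 44000 nM
compound 2 `CC(=O)Nc1ccc(-c2nc3cc(C(F)(F)F)ccc3n2C)cc1` gives 46000 nM
compound 3 `CC(=O)Nc1ccc(-c2nc3cc(C(F)(F)F)ccc3n2C2CCCCC2)cc1` gives 17000 nM

Compound 2 holds the highest of the three numbers in this assay, but only just: the step of a 1.0-fold higher number from compound 1 to compound 2 (0.02 log units; within the scatter) lies within the scatter, so compounds 1 and 2 cannot be ordered against each other. The step of a 2.7-fold lower number from compound 2 to compound 3 (0.43 log units; beyond the scatter) is the one difference beyond the scatter, and it concerns a change on the aromatic nitrogen, not the amide end.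

Compound 4 `Cn1c(-c2ccc(NC(=O)CN3CCN(c4ccccc4)CC3)cc2)nc2cc(C(F)(F)F)ccc21` differs from compound 2 by 4-phenylpiperazin-1-yl in place of hydrogen on a saturated chain carbon bound to a carbonyl carbon. Within the data shown here, the only measured step at this place is a 1.0-fold higher number from compound 1 to compound 2 (0.02 log units; within the scatter), which shows that putting a piperazinyl group there left the number unchanged within the scatter. Among the measured compounds shown here, compound 4 carries a larger group at the same place, and no measured pair speaks to that size. For the measured compounds named here, the expectation is therefore no step beyond the scatter, expressed as a 1.2-fold lower number from compound 2 to compound 4 (0.08 log units; within the scatter), with the range widened to reflect that only one step informs it. Compound 4 is estimated at 38000 nM, between 13000 nM and 90000 nM.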

Compound 4, half-maximal cytotoxic concentration: 1400 nM
The estimate for compound 4 lay 27-fold (1.43 log units) above the measured number; the whole stated range lies above it.
By their numbers in this assay, from the lowest: compound 4; then compound 3; then compounds 1 and 2 (each within the scatter of the next).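

In this assay, the saturated chain carbon bound to a carbonyl carbon no longer looks indifferent to substitution: 4-phenylpiperazin-1-yl in place of hydrogen gives a 33-fold lower number from compound 2 to compound 4 (1.52 log units; beyond the scatter), whereas 4-methylpiperazin-1-yl at the same place differs from hydrogen only within the scatter. The direct comparison of the two piperazinyl compounds locates the change on the amine nitrogen in the ring, where phenyl in place of methyl gives a 31-fold lower number from compound 1 to compound 4 (1.50 log units; beyond the scatter), so the presence of a piperazinyl group alone does not set the number. No available evidence bears on the reason for this change.

Going by these compounds, it remains open whether the lower number requires an aromatic ring on that nitrogen, or whether ethyl, cyclohexyl or benzyl there would give a similar result. A phenyl ring carrying a fluorine or methoxy substituent would test how far the step depends on the unsubstituted phenyl group.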